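A few compounds are considered here, and "the series" means these few. Any claim that something is new, unique, unknown or untested is made for them only; others in the source may bear on it.

Measured compounds in an ADME assay on HepG2 cells (Homo sapiens) for cytotoxicity, read by CellTiter-Glo and ATP content, with a stated time of 72 h; on this read-out higher numbers stand for an effect only at larger amounts of compound and lower numbers for an effect already at smaller amounts:

Compound 1, `Cc1ccc(N2CCN(C(=O)C3CCN(C(=O)c4ccc(S(C)(=O)=O)c([N+](=O)[O-])c4)CC3)CC2)cc1`, gives > 27000 nM, which is a limit of this assay and not a number.
Compound 2, `CN(Cc1cccc(F)c1)C(=O)CNC(=O)c1ccc(S(C)(=O)=O)c([N+](=O)[O-])c1`, gives > 27000 nM, again a limit.
Compound 3, `CS(=O)(=O)c1ccc(C(=O)NCCCC(=O)N2Cc3ccccc3C2)cc1[N+](=O)[O-]`, gives > 27000 nM, again a limit.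

All three measured compounds share a core carrying a methylsulfonyl group and a nitro group, and none of them reaches a measurable effect in this assay. Compound 1 therefore stands where every other measured value stands: at the limit of the assay, as summarised in the limit of > 27000 nM in this assay, at which 3 of the 3 values shown sit. For the measured compounds named here, no pair of measured compounds differs in a single place, so no step between measured compounds can be sized.

Compound 4, `CS(=O)(=O)c1ccc(C(=O)N2CCC(C(=O)N3CCN(c4ccc(F)cc4)CC3)CC2)cc1[N+](=O)[O-]`, differs from compound 1 by fluoro in place of methyl on an aromatic carbon. Going by the values given here, since every measured value sits at the limit, the account can only say that compound 1, compound 2 and compound 3 all lie beyond the measurable range, and no direction for the step in this assay can be read from them. For compound 4 the expectation is that the assay again reports a limit, an expected 27000 nM with a range from 20000 nM to 60000 nM. The expected step of a number no higher from compound 1 to compound 4 (the limit leaves the size open) is thus no change beyond the scatter, an estimate only.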

Compound 4, half-maximal effective concentration: > 27000 nM
Compound 4: only a limit was reported (the forecaster's own chance of this, stated with the estimate: 85%); the middle value lies on the limit itself.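

In this assay, compound 1 and compound 4 both give only limits, so no step can be read for fluoro in place of methyl on an aromatic carbon: the limit of > 27000 nM in this assay, at which 4 of the 4 values shown sit.

The compounds shown leave open what change to the shared core, if any, would produce a measurable effect in this assay.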